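Fluoro in Place of Methoxy on a Shared Core

The source may report more compounds than this note shows. Statements on the series, on what has been measured and on what is new or still open speak of the compounds shown alone.

Compound 1 `COc1cc(CNc2nc3cc(N)cc(N)c3nc2-c2ccccc2)cc(OC)c1OC`: < 50200 nM
Compound 2 `COc1ccc(CNc2nc3cc(N)cc(N)c3nc2-c2ccccc2)cc1`: < 100000 nM
Compound 3 `COc1ccc(Sc2nc3cc(N)cc(N)c3nc2-c2ccccc2)cc1`: < 100000 nM

The three measured compounds share one core and were tested in a functional assay on K562 cells (Homo sapiens) for inhibition, read by sulforhodamine B assay, with a stated time of 48 h; on this read-out higher numbers stand for lower toxicity in this test and lower numbers for higher toxicity in this test. For compound 1 the value < 50200 nM is a limit of the assay, not a number. For compound 2 the value < 100000 nM is likewise a limit. For compound 3 the value < 100000 nM is also a limit. Compound 3 therefore stands only at a limit, and the two other values shown are limits as well: two of the three sit at the limit of < 100000 nM in this assay, at which 2 of the 3 values shown sit, and one sits at the limit of < 50200 nM in this assay, at which 1 of the 3 values shown sits. Among the compounds with values here, no step between two measured compounds that differ in a single place is available, so nothing measured tells how large a change at the aromatic ring attached through sulfur may be.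

Compound 4 `Nc1cc(N)c2nc(-c3ccccc3)c(Sc3ccc(F)cc3)nc2c1` differs from compound 3 in one place: fluoro in place of methoxy on an aromatic carbon. With only limits to go on, no step beyond the usual scatter is expected in this assay in either direction from compound 3 to compound 4, and compound 4 is expected to remain near the limit. The estimate for compound 4 is 50000 nM, between 10000 nM and 200000 nM, which corresponds to an expected step that the limit leaves unreadable from compound 3 to compound 4.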

Compound 4, concentration lethal to 50% of the cells: < 100000 nM
Compound 4: only a limit was reported; the forecaster's own chance of this, stated with the estimate: 60%; the middle value does not contradict the limit.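

In this assay, within the data shown here, compound 3 and compound 4 are both reported only as limits, and no step between them can be read for fluoro in place of methoxy. The compounds shown leave open where the actual values lie and whether this exchange on the aromatic ring alters the read-out.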